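This account rests on a few compounds, and the source may have more. Where it says the series, first, only, none or still open, it means among the compounds named here.

Measured so far in a physicochemical assay for lipophilicity; a higher number here means a more lipophilic compound, a lower number a more polar compound:

Compound 1 `CC[C@@H](c1ccccc1)n1nc(C(=O)NC)cc1C(=O)N[C@H]1[C@@H]2C[C@H](O)C[C@@H]21` gives 3.6.
Compound 2 `CNC(=O)c1cc(C(=O)N[C@H]2[C@@H]3C[C@@H](O)C[C@@H]32)n([C@@H](C)c2ccccc2)n1` gives 3.2.
Compound 3 `CCNC(=O)c1cc(C(=O)NC)nn1[C@@H](C)c1ccccc1` gives 3.7.

Compound 2 has the lowest number of the three, and both gaps to it lie beyond the scatter: compound 2 gives 3.2, compound 1 gives 3.6 and so stands higher, and compound 3 stands higher still. The unmeasured compound 4 `CC[C@@H](c1ccccc1)n1nc(C(=O)NC)cc1C(=O)N[C@H]1[C@@H]2C[C@@H](O)C[C@@H]21` differs from compound 2 in one place: methyl in place of hydrogen on a saturated chain carbon, two bonds along the chain from an aromatic carbon and an aromatic nitrogen. Among the compounds with values here, no measured pair changes exactly this group. Within the data shown here, the single measured step, a number 0.50 log units higher from compound 2 to compound 3 (beyond the scatter), swaps a different group on an amide-type nitrogen, so it shows only how far one small change on this core can move the number. Compound 1 carries the same chain as compound 4, but also differs from compound 2 in another place, so only its value can be set beside that of compound 2. A small, upward move is therefore expected for compound 4, of about a number 0.40 log units higher from compound 2 to compound 4 (beyond the scatter). The estimate for compound 4 in this assay is 3.6, within a range from 3.3 to 3.9.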

Compound 4, distribution coefficient: 3.3
The estimate for compound 4 lay 0.30 log units above the measured number, within the range that was stated.
By their numbers in this assay, from the lowest: compounds 2, 4, 1 and 3 (each within the scatter of the next, the first and the last beyond it).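

In this assay, methyl in place of hydrogen on a saturated chain carbon, which turns 1-phenylethyl into 1-phenylpropyl, gives a number 0.10 log units higher from compound 2 to compound 4 (within the scatter), so this change at this position cannot be told apart from repeat scatter. The other new step is a number 0.30 log units lower from compound 1 to compound 4 (within the scatter), for a stereocentre at a saturated ring carbon drawn S in compound 1 and R in compound 4, so this change in configuration also stays inside the scatter. This pair tests that one stereocentre on its own: the fact that compounds 1 and 4 differ only in the configuration as drawn.

Going by these compounds, whether a longer chain such as 1-phenylbutyl, or an amine or a carboxylic acid on that chain, would move the number beyond the scatter remains open. The compounds shown also leave open what the opposite configuration at the chain carbon would give.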